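Fluoro to chloro on the core of compound 1

This account rests on a few compounds, and the source may have more. Where it says the series, first, only, none or still open, it means among the compounds named here.

Of the compounds shown here, two have a number so far. In a functional assay on COLO 205 cells (Homo sapiens) for inhibition, read by sulforhodamine B assay, with a stated time of 48 h (a higher number here means a weaker inhibitor, a lower number a stronger inhibitor), compound 1 `O=C1C(=O)N(CCCn2cc(COc3cc(=O)oc4ccccc34)nn2)c2ccc(F)cc21` gives 8880 nM. Among the measured compounds shown here, compound 2 `O=C1C(=O)N(CCCCn2cc(COc3cc(=O)oc4ccccc34)nn2)c2ccc(F)cc21` gives 9110 nM in the same run, and the two values sit within the usual scatter of each other, so neither compound can be set apart from the other on the evidence in hand; no step between measured compounds is therefore available to guide the next move.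

Compound 3 `O=C1C(=O)N(CCCn2cc(COc3cc(=O)oc4ccccc34)nn2)c2ccc(Cl)cc21` keeps the whole of compound 1 except for one exchange: chloro in place of fluoro on an aromatic carbon. Nothing measured in the series speaks to a halogen swap at this position, so the expectation rests on the size of the change alone, one heavy atom for one heavy atom, with no ring, donor, acceptor or charge added or lost. The step from compound 1 to compound 3 is expected to be small, a 1.2-fold lower number from compound 1 to compound 3 (0.07 log units; within the scatter), either direction being possible and none beyond the scatter the most likely outcome. Compound 3 is accordingly estimated at 7500 nM in this assay, with a range from 3000 nM to 19000 nM.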

Compound 3, half-maximal inhibitory concentration: 10700 nM
Compound 3: middle estimate off by 1.4-fold (0.15 log units), on the low side; measured number inside the range.
By their numbers in this assay, from the lowest: compounds 1, 2 and 3 (each within the scatter of the next).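

In this assay, chloro in place of fluoro on an aromatic carbon of the shared core gives a 1.2-fold higher number from compound 1 to compound 3 (0.08 log units; within the scatter), so compound 1 and compound 3 cannot be set apart on this read-out. Among the compounds shown here, this is the first step that can be read at all, and it shows that this position, meta to a fused ring and para to a fused ring, accepts either halogen without a change beyond the scatter, with compound 3 at 10700 nM. No accompanying measurement speaks to the reason for this outcome.

Going by these compounds, a single exchange between two halogens says little about the range of this position, so it remains open whether an amine, a methoxy group or a carboxylic acid on the same aromatic carbon would leave the number equally flat or move it beyond the scatter. Also open, on these data alone, is whether a longer chain between the core and the triazole-bearing part of the molecule, or a change to the coumarin-like end, would separate any compound from this group of closely matched values.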